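The source may report more compounds than this note shows. Statements on the series, on what has been measured and on what is new or still open speak of the compounds shown alone.

Measured compounds:
compound 1, `Cc1nnc2sc(C(=O)NC3CN(c4ncc(C(F)(F)F)cn4)C3)c(N)c2c1C`: 0.048
compound 2, `Cc1c(Cl)nnc2sc(C(=O)NC3CN(c4cc(C(F)(F)F)ncc4Cl)C3)c(N)c12`: 0.019

Both were tested in an ADME assay on a cell-free system (plasma, Homo sapiens) for protein binding; a higher number here means a larger unbound share of the compound, a lower number a smaller unbound share. Within the data shown here, compound 1 stands at the top of the two numbers; the only other compound, compound 2, lies clearly lower, by a gap that goes beyond the usual scatter of repeated measurements. Among the measured compounds shown here, no pair of measured compounds differs in just one place, so no single change has yet been followed on its own.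

Compound 3, `Cc1c(Cl)nnc2sc(C(=O)NC3CN(c4ncc(C(F)(F)F)cn4)C3)c(N)c12`, has not been measured. It is built from compound 1 by one change: chloro in place of methyl on an aromatic carbon. Compound 2 also carries a chloro on its core, but it differs from compound 1 in other places too, so its lower value cannot be laid on the chloro alone. A move towards a smaller unbound share is expected for compound 3, most likely a modest step of size a 1.5-fold lower number from compound 1 to compound 3 (0.18 log units; within the scatter) that may not exceed the scatter. The unbound fraction of compound 3 is estimated at 0.032, within a range from 0.017 to 0.058.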

Compound 3, unbound fraction: 0.022
For compound 3 the middle estimate is 1.5-fold (0.16 log units) above the measured one; the measured number falls inside the stated range.
By their numbers in this assay, from the lowest: compounds 2 and 3 (each within the scatter of the next); then compound 1.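

In this assay the chloro in place of methyl on this aromatic carbon, next to the ring nitrogen, gives a 2.2-fold lower number from compound 1 to compound 3 (0.34 log units; beyond the scatter) with the rest of the molecule unchanged. Among these compounds, this is the first change here that can be followed on its own, and it shows that this single position can shift the unbound share beyond the scatter, even though neither group brings a ring, a hydrogen-bond donor or acceptor, or a net charge. Nothing measured here explains why the unbound share moves with this swap.

As far as these compounds go, it remains open whether an amine, a methoxy group or a nitrile on this same carbon would move the unbound share in the same direction. From the compounds shown here alone, it is also open whether the same swap would give a similar step on a compound with a different group at the far end of the molecule.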